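A hydroxyphenyl swap in a series at the limit

This account rests on a few compounds, and the source may have more. Where it says the series, first, only, none or still open, it means among the compounds named here.

Compound 1 `c1ccc(-c2noc(-c3ccncc3)n2)cc1`: > 1000000 nM
Compound 2 `COc1ccc(-c2noc(-c3ccncc3)n2)cc1OC1CCCC1`: > 1000000 nM
Compound 3 `COc1cc(-c2noc(-c3ccncc3)n2)ccc1OCc1ccccc1`: > 1000000 nM

All three compounds were tested in a functional assay on MCF7 cells (Homo sapiens) for antiproliferative activity, read by MTT assay, with a stated time of 24 h (on this read-out higher numbers stand for weaker inhibition and lower numbers for stronger inhibition), and the picture is uniform: the limit of > 1000000 nM in this assay, at which 3 of the 3 values shown sit. Compound 2 gives > 1000000 nM, which is a limit of the assay and not a number. Its true standing is therefore unknown. Compound 4 `COc1ccc(-c2noc(-c3ccc(O)cc3)n2)cc1OC1CCCC1` carries 4-hydroxyphenyl in place of pyridin-4-yl on an aromatic carbon of compound 2: 4-hydroxyphenyl in place of pyridin-4-yl on an aromatic carbon. Among the compounds with values here, no measured step shows what such a change does. A modest move towards stronger inhibition is expected in this assay, though another result at the limit remains quite possible. The expected change is an at least 5.0-fold lower number from compound 2 to compound 4 (0.69 log units; beyond the scatter). Compound 4 is estimated at 200000 nM, within an expected range of 20000 nM to 1000000 nM.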

Compound 4, half-maximal inhibitory concentration: 390 nM
Estimate against measurement, compound 4: 510-fold (2.71 log units) above, and the stated range ends above it.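

In this assay, within the data shown here, the change to 4-hydroxyphenyl on this aromatic carbon gives an at least 2500-fold lower number from compound 2 to compound 4 (3.40 log units; beyond the scatter) and the only value of the four that lies clear of the limit. Compound 2 gives > 1000000 nM as a limit of the assay and not a number. The true size of the step therefore stays unknown, and it can be read only as a lower bound: the limit of > 1000000 nM in this assay, at which 3 of the 4 values shown sit.

Going by these compounds, what 4-methoxyphenyl or 4-aminophenyl would do at this position stays open. So does whether 4-hydroxyphenyl would have the same effect on the cores of compound 1 and compound 3.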